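Triarylmethane series on breast cancer cells: trimming the side chain

This account rests on a few compounds, and the source may have more. Where it says the series, first, only, none or still open, it means among the compounds named here.

Compound 1, `COc1ccc(/C(=N/OC(C)=O)c2cccc3ccccc23)c(OC)c1OC`, gives > 20000 nM, which is a limit of the assay rather than a number.
Compound 2, `COc1ccc(C(c2ccc(OC(C)CN(C)C)cc2)c2cccc3ccccc23)c(OC)c1OC`, gives 13100 nM.
Compound 3, `COc1ccc(C(O)(Cc2ccccc2)c2cccc3ccccc23)c(OC)c1OC`, gives 10600 nM.

These three compounds share a common core and were tested in a functional assay on MCF7 cells (Homo sapiens) for inhibition, read by sulforhodamine B assay, with a stated time of 48 h; on this read-out higher numbers stand for weaker inhibition and lower numbers for stronger inhibition. Compound 2 holds the highest of the two numbers that are not limits, but its gap to compound 3 is within the scatter, so no order between the two can be read. Compound 1 sits at the limit of > 20000 nM in this assay, at which 1 of the 3 values shown sits.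

The unmeasured compound 4, `COc1ccc(C(c2ccc(O)cc2)c2cccc3ccccc23)c(OC)c1OC`, differs from compound 2 in one place: hydrogen in place of 1-((dimethylamino)methyl)ethyl on an oxygen on an aromatic ring. For the measured compounds named here, no measured pair in this set shows the effect of such a change, so there is no measured step to lean on. With the three neighbours all weak or at the limit, compound 4 is expected to stay in the same weak region; the step from compound 2 is estimated as a 1.4-fold higher number from compound 2 to compound 4 (0.14 log units; within the scatter), a small move toward weaker inhibition that may not exceed the scatter. For compound 4 in this assay the estimate is 18000 nM, with a range from 6000 nM to 50000 nM.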

Compound 4, half-maximal inhibitory concentration: 17500 nM
The estimate for compound 4 lay 1.0-fold (0.01 log units) above the measured number, within the range that was stated.
By their numbers in this assay, from the lowest: compounds 3, 2 and 4 (each within the scatter of the next). At a limit, above all of these: compound 1.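

In this assay, replacing the 1-((dimethylamino)methyl)ethyl group on an oxygen on an aromatic ring with hydrogen gives a 1.3-fold higher number from compound 2 to compound 4 (0.13 log units; within the scatter). For the compounds shown here, this is the first measured step in the set, and it shows that at this position the whole side chain, dimethylamino group included, can be exchanged for hydrogen without a difference that can be told from the scatter. In this pair, the side chain therefore makes no readable contribution to the number in this assay, and nothing measured here offers a reason for that outcome.

The compounds shown leave open whether a methyl group, a longer chain ending in a carboxylic acid, or a piperidine on the same oxygen would give a number that stands clear of the scatter from compound 4. Going by these compounds alone, they also leave open whether this exchange would read the same way if the rest of the molecule carried other groups, since this single pair is the only comparison available at this position.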